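The source may hold more compounds than are shown below. What is called first, only, known or untested is meant among the compounds shown, and "the series" means these compounds.

Measured in an ADME assay on BE(2)-C cells (Homo sapiens) for cytotoxicity, read by MTT assay, with a stated time of 20 h; on this read-out higher numbers stand for lower toxicity in this test and lower numbers for higher toxicity in this test:
- Compound 1 `CC(NC(=O)C1CCN(C(=O)c2cc3ccccc3n2Cc2ccc(Cl)cc2)CC1)c1ccncc1`: 90100 nM
- Compound 2 `CN1CCC(CNC(=O)C2CCN(C(=O)c3cc4ccccc4n3Cc3ccc(Cl)cc3)CC2)CC1`: > 50000 nM

Compound 2 stands at > 50000 nM, which is a limit of the assay and not a number. Its exact place on the scale is therefore unknown.

The next compound, not yet measured in this assay, is compound 3 `O=C(NCCn1ccnc1)C1CCN(C(=O)c2cc3ccccc3n2Cc2ccc(Cl)cc2)CC1`. The change is (1H-imidazol-1-yl)methyl in place of 1-methylpiperidin-4-yl on a saturated chain carbon bound to an amide-type nitrogen. In words, (1H-imidazol-1-yl)methyl replaces 1-methylpiperidin-4-yl on a saturated chain carbon bound to an amide-type nitrogen. Cut one bond further out, this reads (1-methylpiperidin-4-yl)methyl to 2-(1H-imidazol-1-yl)ethyl.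

For the measured compounds named here, only one measured step bears on this change: a step that the limit leaves unreadable from compound 1 to compound 2. It has no readable size, so no size can be carried over to the new step. Going by the values given here, the sole numerical anchor is compound 1, which carries 1-(pyridin-4-yl)ethyl on that amide-type nitrogen and gives 90100 nM. No step beyond the scatter and no firm direction can be expected on this basis.

The expected step is a step that the limit leaves unreadable from compound 2 to compound 3, an estimate that remains loose. Compound 3 is estimated at 70000 nM, with an expected range of 25000 nM to 150000 nM.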

Compound 3, half-maximal cytotoxic concentration: 99600 nM
The estimate for compound 3 lay 1.4-fold (0.15 log units) below the measured number; low and high end bracket the measured number.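

In this assay, for the compounds shown here, 2-(1H-imidazol-1-yl)ethyl in place of 1-(pyridin-4-yl)ethyl on an amide-type nitrogen gives the first readable step at this position (a 1.1-fold higher number from compound 1 to compound 3 (0.04 log units; within the scatter)). Two side chains that differ in their five-membered and six-membered aromatic rings therefore leave the read-out within the scatter, so for this pair the change of ring makes no measurable difference in this test. Compound 2 gives > 50000 nM, which is a limit of the assay and not a number, and both steps that involve compound 2 cannot be read because of that limit: the limit of > 50000 nM in this assay, at which 1 of the 3 values shown sits.

Where the 1-methylpiperidin-4-yl side chain really lies relative to the two aromatic side chains stays open, and the only readable step here offers no sign of any group at this amide-type nitrogen that moves the number beyond the scatter. A carboxylic acid on the chain, a primary amine, or a longer chain ending in 1H-imidazol-1-yl would show whether this position stays as flat once the group is of a different kind or sits further from the amide-type nitrogen.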